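Ethoxy in place of nitro on an aromatic carbon

The compounds below may be only part of what the source reports. "The series", "measured", "known", "first", "only" and "open" are said of these compounds alone.

compound 1 `CN(C)c1ccc(/C=C/c2cc(=O)c(O)c[nH]2)cc1` gives 3410 nM
compound 2 `O=c1cc(/C=C/c2ccc([N+](=O)[O-])cc2)[nH]cc1O` gives 4790 nM

Both numbers come from a functional assay, with a stated time of 10 min (a higher number here means a weaker inhibitor, a lower number a stronger inhibitor), and they lie within the scatter of each other, so compound 2 cannot be told apart from compound 1 on these data. The next compound to be tested, compound 3 `CCOc1ccc(/C=C/c2cc(=O)c(O)c[nH]2)cc1` and still without a number, carries ethoxy in place of nitro on an aromatic carbon and otherwise matches compound 2. Within the data shown here, only one measured step bears on this change, namely a 1.4-fold higher number from compound 1 to compound 2 (0.15 log units; within the scatter) for nitro in place of dimethylamino on an aromatic carbon. Among the measured compounds shown here, no compound with ethoxy has yet been measured in this assay and this single step is a thin guide. For the measured compounds named here, with only that step to go on, no change beyond the scatter is expected in either direction. The estimated step is a 1.2-fold lower number from compound 2 to compound 3 (0.08 log units; within the scatter) on this reasoning. Compound 3 is therefore expected at 4000 nM with an estimated range from 1500 nM to 10000 nM in this measurement.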

Compound 3, half-maximal inhibitory concentration: 8120 nM
For compound 3 the middle estimate is 2.0-fold (0.31 log units) below the measured one; the measured number falls inside the stated range.
By their numbers in this assay, from the lowest: compounds 1, 2 and 3 (each within the scatter of the next, the first and the last beyond it).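

On the aromatic carbon para to a large group, ethoxy in place of nitro gives in this assay a 1.7-fold higher number from compound 2 to compound 3 (0.23 log units; within the scatter) and so cannot be told apart from nitro on these data. Ethoxy in place of dimethylamino gives a 2.4-fold higher number from compound 1 to compound 3 (0.38 log units; beyond the scatter) and is the first single change in this series to pass the scatter, although only modestly, which shows that the group at this position can shift the number, whereas the earlier pair showed no measurable difference. Nothing available explains this small difference between ethoxy and dimethylamino, and the comparison rests on these three compounds alone.

Going by these compounds, the three groups tested so far give numbers that lie close together, so it remains open whether plain hydrogen, methoxy, a longer alkoxy chain such as propoxy, a primary amine or a carboxylic acid at this position would move the number much further in either direction. On these data alone, it is also open whether the same groups would behave alike at another place on this aromatic ring, or whether the modest step between ethoxy and dimethylamino would hold on a wider set.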